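The source may hold more compounds than are shown below. What is called first, only, known or untested is meant among the compounds shown, and "the series" means these compounds.

Measured so far in an ADME assay on a cell-free system (plasma, Homo sapiens) for protein binding
compound 1 `Cc1cc(Nc2ccc(C(F)(F)F)cc2)n2nc(CCO)nc2n1` gives 67%
compound 2 `CCc1nc2nc(C)cc(Nc3cccc(Cl)c3)n2n1` gives 86.7%
compound 3 `Cc1cc(Nc2ccc(Cl)cc2)n2nc(C(C)C)nc2n1` gives 84.9%

Compound 1 has the lowest binding of the three and so the highest unbound fraction. Its gaps in unbound fraction to compound 3 and to compound 2 both lie beyond the scatter.

Compound 4 `COCCc1nc2nc(C)cc(Nc3ccc(C(F)(F)F)cc3)n2n1` has not yet been measured. Compared with compound 1 it carries methyl in place of hydrogen on an oxygen on a saturated carbon in one place, turning 2-hydroxyethyl into 2-methoxyethyl, that is, methyl in place of hydrogen on an oxygen on a saturated carbon.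

Within the data shown here, no measured pair isolates this change, so the evidence is indirect and thin. Neither compound 2 nor compound 3 carries a hydroxy group, and both differ from compound 1 at other places as well. Compound 2 stands at 86.7% and compound 3 at 84.9% in this assay against the lower value of compound 1. A step towards higher binding and a lower unbound fraction, beyond the scatter, is therefore expected, with a 2.2-fold lower unbound fraction from compound 1 to compound 4 (0.34 log units; beyond the scatter) as its estimated size. For compound 4 the estimated value is 85% within an expected range of 74% to 93%.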

Compound 4, plasma protein binding: 73.7%
Beside the measured number, compound 4's estimate is 1.8-fold (0.24 log units) (unbound fraction) below it; the whole stated range lies above it.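

In this assay, among these compounds, the series now has its first pair differing in one place, and turning 2-hydroxyethyl into 2-methoxyethyl gives a 1.3-fold lower unbound fraction from compound 1 to compound 4 (0.10 log units; within the scatter) as the only direct reading at this position. Methyl in place of hydrogen on an oxygen on a saturated carbon therefore leaves plasma protein binding within what repeated measurements would show, something the earlier compounds could not establish as each differs from compound 1 in more than one place. No measurement is at hand that bears on the reason for this result.

The compounds shown leave open whether an amine or a carboxylic acid at the end of this chain, or a longer ether chain, would move plasma protein binding beyond the scatter, as this single pair covers only the exchange of hydroxy for methoxy. They also leave open whether the same exchange would stay within the scatter in a compound carrying a group other than trifluoromethyl on the shared core.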